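Compound 1 Stripped to Its Core: What to Expect

The source may report more compounds than this note shows. Statements on the series, on what has been measured and on what is new or still open speak of the compounds shown alone.

Compound 1 `CCN(CC)C(=O)COc1ccc2cc(C(O)(C(F)(F)F)C(F)(F)F)c(O)cc2c1` was tested in an assay on isolated protein for inhibition of receptor-type tyrosine-protein phosphatase C (Homo sapiens), read by spectrophotometry; on this read-out lower numbers stand for stronger inhibition and higher numbers for weaker inhibition. In this assay compound 1 gives > 20000 nM, which is a limit of the assay rather than a measured number. Its companion compound 2 `CC(C)c1ccc(NC(=O)COc2ccc3cc(C(O)(C(F)(F)F)C(F)(F)F)c(O)cc3c2)cc1` gives 7800 nM in this assay. Among the measured compounds shown here, the one step measured so far, an at least 2.5-fold lower number from compound 1 to compound 2 (0.40 log units; beyond the scatter), shows that the amide substituent matters, though on the compound 1 side only a limit is known (the limit of > 20000 nM in this assay, at which 1 of the 2 values shown sits).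

Compound 3 `Oc1cc2ccccc2cc1C(O)(C(F)(F)F)C(F)(F)F` moves in a different direction: hydrogen in place of (diethylcarbamoyl)methoxy on an aromatic carbon. For the measured compounds named here, no measured step removes the whole side chain, so the step involving compound 2 bears on it only loosely. Since compound 1 already sits at a limit, compound 3 is expected to give 20000 nM, somewhere between 5000 nM and 80000 nM. This estimate corresponds to a step of a number no higher from compound 1 to compound 3 (the limit leaves the size open), with a fair chance that the assay again reports only a limit.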

Compound 3, half-maximal inhibitory concentration: 112000 nM
Compound 3: the middle estimate sits 5.6-fold (0.75 log units) below what was measured; measured number above the stated range.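

No new step can be read from compound 1 to compound 3, because compound 1 stands only at a limit: the limit of > 20000 nM in this assay, at which 1 of the 3 values shown sits. The compounds shown leave open how far the number shifts when (diethylcarbamoyl)methoxy alone gives way to hydrogen.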